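Removing Iodine From a Weak Adenosine Receptor Ligand

The source may hold more compounds than are shown below. What is called first, only, known or untested is meant among the compounds shown, and "the series" means these compounds.

Of the compounds shown here, three have been measured in an in vitro assay on HEK293 cells for displacement of a labelled ligand from adenosine receptor A2b (Homo sapiens); a higher number here means a weaker inhibitor, a lower number a stronger inhibitor. Compound 1 `CCCCn1c(=O)c2nc(-c3cnn(Cc4ccccc4)c3)[nH]c2n(CCCC)c1=O` gives 980 nM. Compound 3 `CCCn1c(=O)c2nc(-c3cnn(Cc4ccccc4C(F)(F)F)c3)[nH]c2n(CCC)c1=O` gives 37 nM. Compound 2 `CCCn1c(=O)c2c(nc(-n3cc(I)cn3)n2Cc2ccccc2)n(CCC)c1=O` gives only a limit, > 5800 nM, and not a number. Among the three values, compound 2 sits at the weak end, at the limit of the assay (the limit of > 5800 nM in this assay, at which 1 of the 3 values shown sits). No pair of these compounds differs in just one place, so no single step has been measured.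

Compound 4 `CCCn1c(=O)c2c(nc(-n3cccn3)n2Cc2ccccc2)n(CCC)c1=O` differs from compound 2 in one place: hydrogen in place of iodo on an aromatic carbon. With the starting point known only as a limit, the size of this step cannot be read from the measured compounds. A change no larger than the usual scatter, in either direction, is expected, and compound 4 is therefore expected to remain a weak binder. Compound 4 is estimated at 6000 nM, with a range from 1500 nM to 20000 nM. The expected step is a step that the limit leaves unreadable from compound 2 to compound 4. It is likely that the assay again reports only a limit for compound 4.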

Compound 4, inhibition constant: > 5800 nM
Compound 4: no number, only a limit (the forecaster's own chance of this, stated with the estimate: 55%); the middle value lies beyond the limit too.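

No step can be read from compound 2 to compound 4, because each of these two compounds gives only a limit in this assay, not a number: the limit of > 5800 nM in this assay, at which 2 of the 4 values shown sit.

The compounds shown leave open whether hydrogen in place of iodo on an aromatic carbon changes binding at all.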